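The source may hold more compounds than are shown below. What is called first, only, known or untested is meant among the compounds shown, and "the series" means these compounds.

Measured so far in a functional assay on A549 cells (Homo sapiens) for cytotoxicity, read by colorimetric assay and MTT assay; a lower number here means a stronger inhibitor, a higher number a weaker inhibitor:
- compound 1 `COc1ccc(-c2cc3c(OC)ccc(OC)c3nc2O)cc1`: 10000 nM
- compound 2 `COc1ccc(-c2cc3c(OC)cc(OC)cc3n(CCCC#N)c2=O)cc1`: 10000 nM

Compound 2, at 10000 nM, stands level with compound 1, which reads 10000 nM. Any gap between them would have to exceed the usual scatter of repeated measurements to count, and here there is none. Going by the values given here, these two compounds differ in more than one place, so they offer no clean measured step to learn from.

Compound 3 `CCN(CC)C(=O)CCn1c(=O)c(-c2ccc(OC)cc2)cc2c(OC)cc(OC)cc21` keeps the core of compound 2 and carries diethylcarbamoyl in place of cyanomethyl, on a saturated chain carbon, two bonds along the chain from an aromatic nitrogen: diethylcarbamoyl in place of cyanomethyl on a saturated chain carbon, two bonds along the chain from an aromatic nitrogen. The same difference can also be read as 3-cyanopropyl to 2-(diethylcarbamoyl)ethyl.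

The data show nothing about how a change at this chain moves the number in this assay. Among the compounds with values here, the only anchor is compound 2 at 10000 nM, so the expectation is no step beyond the scatter, in either direction. The expected outcome is no change at the digits printed from compound 2 to compound 3 (within the scatter). For compound 3 the estimated value is 10000 nM, with an expected range from 3000 nM to 30000 nM.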

Compound 3, half-maximal inhibitory concentration: 10000 nM
Beside the measured number, compound 3's estimate shows no gap at the digits printed; the range from low to high includes it.
By their numbers in this assay, from the lowest: compounds 1, 2 and 3 (each within the scatter of the next).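

In this assay, going by these compounds alone, putting diethylcarbamoyl in place of cyanomethyl on a saturated chain carbon, two bonds along the chain from an aromatic nitrogen, gives no change at the digits printed from compound 2 to compound 3 (within the scatter) and so provides the first clean reading of a single change in this set. At this position, the assay does not separate the two groups, even though the entering group has more heavy atoms and carries a carbonyl where the leaving group carries a nitrile. No measurement here offers an explanation for this flat step.

Going by these compounds, whether any other group at this chain can move the reading remains open: an amine, a carboxylic acid or a longer chain might read differently or just the same. This one step also says nothing about changes elsewhere on the shared core, such as replacing a methoxy group with a hydroxyl or a fluorine.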